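This account rests on a few compounds, and the source may have more. Where it says the series, first, only, none or still open, it means among the compounds named here.

Measured compounds in a functional assay on PC-3 cells (Homo sapiens) for antiproliferative activity, read by MTT assay, with a stated time of 72 h; a lower number here means a stronger inhibitor, a higher number a weaker inhibitor:
compound 1, `C=CC(=O)Nc1cc2c(N3CCc4ccccc43)ncnc2cc1O[C@@H]1CCOC1`: 2710 nM
compound 2, `CC(C)=CC(=O)Nc1cc2c(N3CCc4ccccc43)ncnc2cc1O[C@@H]1CCOC1`: 4620 nM
compound 3, `CC/C=C/C(=O)Nc1cc2c(N3CCc4ccccc43)ncnc2cc1O[C@@H]1CCOC1`: 9590 nM

The three share one core and differ only in the group on the carbonyl carbon of the amide. Compound 3 gives the highest number of the three, so it is the weakest inhibitor: the step is a 2.1-fold higher number from compound 2 to compound 3 (0.32 log units; beyond the scatter) and a 3.5-fold higher number from compound 1 to compound 3 (0.55 log units; beyond the scatter).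

Compound 4 is `CCC/C=C/C(=O)Nc1cc2c(N3CCc4ccccc43)ncnc2cc1O[C@@H]1CCOC1`. It differs from compound 3 by methyl in place of hydrogen on a saturated chain carbon, two bonds along the chain from a double-bonded chain carbon, so the chain on the carbonyl carbon grows by one carbon.

Two measured steps speak to chain growth here. Lengthening the chain from vinyl to but-1-en-1-yl gave a 3.5-fold higher number from compound 1 to compound 3 (0.55 log units; beyond the scatter), while adding two methyls to the vinyl gave only a 1.7-fold higher number from compound 1 to compound 2 (0.23 log units; within the scatter). Both point the same way: added carbon on this chain does not lower the number and tends to raise it. A further small rise in this assay is therefore expected, modest and possibly within the scatter.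

For compound 4 the expected step is a 1.5-fold higher number from compound 3 to compound 4 (0.16 log units; within the scatter). Compound 4 is expected to give about 14000 nM, within a range from 6000 nM to 35000 nM.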

Compound 4, half-maximal inhibitory concentration: 9230 nM
Compound 4: middle estimate off by 1.5-fold (0.18 log units), on the high side, within the range that was stated.
By their numbers in this assay, from the lowest: compounds 1, 2, 4 and 3 (each within the scatter of the next, the first and the last beyond it).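

In this assay, methyl in place of hydrogen on a saturated chain carbon, two bonds along the chain from a double-bonded chain carbon, gives a 1.0-fold lower number from compound 3 to compound 4 (0.02 log units; within the scatter), so the two compounds cannot be told apart. The earlier compounds shown here showed only that but-1-en-1-yl separates from vinyl; pent-1-en-1-yl also stands clear of vinyl, with a 3.4-fold higher number from compound 1 to compound 4 (0.53 log units; beyond the scatter), but this extra carbon adds no measurable distance, and the step of a 2.0-fold higher number from compound 2 to compound 4 (0.30 log units; within the scatter) leaves the branched 2-methylprop-1-en-1-yl and the pent-1-en-1-yl chain inseparable. No measurement shown offers an explanation for this level step.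

Going by these compounds, whether a longer chain, such as hex-1-en-1-yl, would stay on the same level remains open. So does the effect of a chain carrying an amine, such as dimethylamine, on the shared core.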